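The compounds below may be only part of what the source reports. "The series", "measured", "known", "first", "only" and "open" are said of these compounds alone.

Compound 1 `COc1ccc(O)c2c(=O)ccn(C)c12`: > 40000 nM
Compound 2 `COc1cc2nccc(O)c2c(O)c1OC`: > 40000 nM

Both entries are limits, not numbers, so (the limit of > 40000 nM in this assay, at which 2 of the 2 values shown sit). In a functional assay on L1210 cells (Mus musculus) for antiproliferative activity (on this read-out higher numbers stand for weaker inhibition and lower numbers for stronger inhibition), compound 2 stands at the limit > 40000 nM. Compound 3 `COc1cc2nccc(O)c2c(OC)c1OC` carries methyl in place of hydrogen on an oxygen on an aromatic ring, hydroxy to methoxy: methyl in place of hydrogen on an oxygen on an aromatic ring. Among the compounds with values here, no measured step shows what this change does in this assay, so no step beyond the scatter is expected, and no direction can be given with confidence. The estimated step of a number no higher from compound 2 to compound 3 (the limit leaves the size open) is expected to stay small. Compound 3 is estimated at 40000 nM, with an expected range of 15000 nM to 100000 nM.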

Compound 3, half-maximal inhibitory concentration: > 40000 nM
Compound 3: a limit, no number (the forecaster's own chance of this, stated with the estimate: 75%); the middle value lies on the limit itself.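

Compound 2 and compound 3 both stand at a limit rather than a number, so no step between them can be read: the limit of > 40000 nM in this assay, at which 3 of the 3 values shown sit.

Going by these compounds, what hydroxy to methoxy does in this assay remains open.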